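This account rests on a few compounds, and the source may have more. Where it says the series, first, only, none or still open, it means among the compounds named here.

Compound 1 `O=c1cc(-c2ccccc2)oc2cccc(OCCCCCCCN3CCC(O)CC3)c12` gives 65 nM in an assay on isolated protein (Cavia porcellus) with Sigma non-opioid intracellular receptor 1 (Homo sapiens) as the target, read by radioligand binding; on this read-out higher numbers stand for weaker inhibition and lower numbers for stronger inhibition. Compound 2 `CN(C)CCCCCCCOc1ccc2oc(-c3ccccc3)cc(=O)c2c1` gives 188 nM in this assay. Compound 3 `O=c1cc(-c2ccccc2)oc2ccc(OCCCCCCN3CCNC(CCO)C3)cc12` gives 94 nM in this assay.

Among these three, compound 2 carries the highest number. The step of a 2.0-fold lower number from compound 2 to compound 3 (0.30 log units; within the scatter) is the smaller of its two gaps, and compound 1 shows a number lower than that of compound 2 by a margin that goes beyond the scatter. The unmeasured compound 4 `CCOC(=O)C1CCN(CCCCCCOc2ccc3oc(-c4ccccc4)cc(=O)c3c2)CC1` is reached from compound 2 by a single change: 4-(ethoxycarbonyl)piperidin-1-yl in place of (dimethylamino)methyl on a saturated chain carbon, six bonds along the chain from an oxygen on an aromatic ring. Among the measured compounds shown here, the one measured step that speaks to this change is the one in which the dimethylamino end of the chain was likewise exchanged for a ring-bearing amine; it brought a 2.0-fold lower number from compound 2 to compound 3 (0.30 log units; within the scatter), a shift too small to count as real. Compound 1, whose chain also ends in a ring-bearing amine, shows the lowest number of the three, but with only these two comparisons no firm pattern can be claimed. For compound 4 the expected step is therefore a 1.9-fold lower number from compound 2 to compound 4 (0.27 log units; within the scatter), a modest lowering that may well stay within the scatter. Compound 4 is estimated at 100 nM, with a range from 40 nM to 250 nM.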

Compound 4, half-maximal inhibitory concentration: 102 nM
For compound 4 the middle estimate is 1.0-fold (0.01 log units) below the measured one; low and high end bracket the measured number.
By their numbers in this assay, from the lowest: compounds 1, 3, 4 and 2 (each within the scatter of the next, the first and the last beyond it).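

On the saturated chain carbon six bonds along the chain from an oxygen on an aromatic ring, a far larger end group can take the place of the small open one without a clear shift in this assay: 4-(ethoxycarbonyl)piperidin-1-yl has 11 heavy atoms and a six-membered non-aromatic ring, (dimethylamino)methyl has 4 heavy atoms and no ring, yet the result is a 1.8-fold lower number from compound 2 to compound 4 (0.27 log units; within the scatter). Among the compounds shown here, two different ring-bearing ends can also be set side by side at this place for the first time, and exchanging 3-(2-hydroxyethyl)piperazin-1-yl for 4-(ethoxycarbonyl)piperidin-1-yl gives a 1.1-fold higher number from compound 3 to compound 4 (0.04 log units; within the scatter), so these compounds 2, 3 and 4 do not separate by end group in this assay. No other measurement here offers an explanation for how closely these numbers lie.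

Still open, as far as these compounds go, is whether any end group at this place can move the number beyond the scatter, for example a piperidine carrying a free carboxylic acid in place of the ethoxycarbonyl group, or a morpholine ring. Also open, from the compounds shown here alone, is whether these end groups would behave alike on a longer chain.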